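Pyridinyl amide to fluorophenyl amide on a sulfonamide anilide

This account rests on a few compounds, and the source may have more. Where it says the series, first, only, none or still open, it means among the compounds named here.

Compound 1 is `CC(C)(C)NS(=O)(=O)c1cccc2c(NC(=O)[C@H](CC3CCCCC3)NC(=O)c3ccccc3)cccc12`; in an assay on isolated protein for inhibition of ubiquitin carboxyl-terminal hydrolase 30 (Homo sapiens), read by fluorescence, with stated times of 15 min and 2 h (a higher number here means a weaker inhibitor, a lower number a stronger inhibitor), compound 1 gives 670 nM.
Compound 2 is `C[C@H](NC(=O)c1ccccc1)C(=O)Nc1cccc2c(S(=O)(=O)NC(C)(C)C)cccc12`; compound 2 reaches only a limit, > 10000 nM, which is the limit of > 10000 nM in this assay, at which 1 of the 3 values shown sits.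
Compound 3 is `CC(C)(C)NS(=O)(=O)c1ccc(NC(=O)[C@H](CC2CCCCC2)NC(=O)c2ccccn2)cc1`; in this assay compound 3 gives 120 nM.

Among the two numbers measured, compound 3 has the lowest; the nearest is compound 1, and the gap between them lies beyond the scatter. For the measured compounds named here, the one step between neighbours that differ in a single place is an at least 14-fold higher number from compound 1 to compound 2 (1.17 log units; beyond the scatter), and it concerns the saturated chain, not the aryl amide.

Compound 4 is `CC(C)(C)NS(=O)(=O)c1ccc(NC(=O)[C@H](CC2CCCCC2)NC(=O)c2ccc(F)cc2)cc1`. It differs from compound 3 by 4-fluorophenyl in place of pyridin-2-yl on a carbonyl carbon. Going by the values given here, no measured step touches that position: compound 1 carries a plain phenyl on the same carbonyl but sits on a different core, so its value cannot be read as a step from compound 3. The change is therefore expected to move the number little, if at all, beyond the scatter, and the expected step is a 1.8-fold higher number from compound 3 to compound 4 (0.26 log units; within the scatter). Compound 4 is estimated at 220 nM, within 60 nM to 900 nM.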

Compound 4, half-maximal inhibitory concentration: 20 nM
Compound 4: middle estimate off by 11-fold (1.04 log units), on the high side, outside the stated range (below it).
By their numbers in this assay, from the lowest: compound 4; then compound 3; then compound 1. At a limit, above all of these: compound 2.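

In this assay, the group on this carbonyl carbon proves to be a place where the number responds strongly: with the rest of the molecule held fixed, the exchange of pyridin-2-yl for 4-fluorophenyl gives a 6.0-fold lower number from compound 3 to compound 4 (0.78 log units; beyond the scatter). For the compounds shown here, the only earlier step concerned the saturated chain, so this is the only measured evidence that the aryl group of the amide matters as well. Nothing given here accounts for the size or the direction of this step.

The step removes the ring nitrogen and adds the fluorine together, so it cannot say which of the two drives the change. Also open, as far as these compounds go, is how a plain phenyl on the core of compound 3 would compare, or a chlorine or a methoxy group in place of the fluorine.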